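Chloro for Fluoro on the Hydroxymethyl-Bearing Ring

This account rests on a few compounds, and the source may have more. Where it says the series, first, only, none or still open, it means among the compounds named here.

Measured so far in a functional assay on cells for positive allosteric modulation of G-protein coupled receptor 68 (Homo sapiens), read by a luciferase reporter and cAMP accumulation, with a stated time of 30 min, at pH 6.8 and pH 8.3, in the presence of a further agent that is not named here; on this read-out lower numbers stand for lower potency and higher numbers for higher potency (the scale is a negative logarithm):
compound 1, `Nc1nc(NCc2ccccc2)nc(-c2cccc(F)c2CO)n1`, gives 4.01
compound 2, `Nc1nc(NCc2ccccc2)nc(-c2ccc(F)cc2CO)n1`, gives 4.58
compound 3, `Nc1nc(NCc2ccccc2)nc(-c2cc(F)ccc2CO)n1`, gives 4.58

Compound 2 stands level with compound 3 at the digits shown, and together these two are the highest of the three numbers; its nearest neighbour is compound 3, with no change within the scatter, and its furthest is compound 1, which lies lower, beyond the scatter. Compound 4, `Nc1nc(NCc2ccccc2)nc(-c2ccc(Cl)cc2CO)n1`, differs from compound 2 by chloro in place of fluoro on an aromatic carbon. Within the data shown here, no step between measured compounds mirrors this change, so its size is not known from the data; a small gain in this assay, or none beyond the scatter, is expected, as a number 0.22 log units higher from compound 2 to compound 4 (within the scatter). Compound 4 is therefore estimated at 4.8, within a range from 4.3 to 5.3.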

Compound 4, negative logarithm of the antagonist equilibrium constant: 4.76
For compound 4 the middle estimate is 0.04 log units above the measured one, within the range that was stated.
By their numbers in this assay, from the lowest: compound 1; then compounds 2, 3 and 4 (each within the scatter of the next).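

In this assay, chloro in place of fluoro on this aromatic carbon, para to a large group and meta to a hydroxymethyl group, gives a number 0.18 log units higher from compound 2 to compound 4 (within the scatter), so the position holds either halogen with no change beyond the scatter. Among these compounds, the earlier compounds varied only where fluoro sits on the ring, whereas this step is the first to change the atom itself. Nothing measured here accounts for this result.

From the compounds shown here alone, whether bromo, methyl or an amine would be tolerated at this position remains open. Also open, going by these compounds, is whether chloro would match fluoro at the ring positions where compound 1 and compound 3 carry fluoro.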